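A few compounds are considered here, and "the series" means these few. Any claim that something is new, unique, unknown or untested is made for them only; others in the source may bear on it.

Measured so far:
Compound 1 `N#CC1=C(N)Oc2c(N)cc3nc4ccccc4nc3c2C12C(=O)N(Cc1cnnn1-c1cccc(Br)c1)c1ccccc12` gives > 50000 nM in an ADME assay on L02 cells (Homo sapiens) for antiproliferative activity, read by MTT assay, with a stated time of 48 h (on this read-out lower numbers stand for stronger inhibition and higher numbers for weaker inhibition), which is a limit of the assay and not a number.
Compound 2 `N#CC1=C(N)Oc2c(N)cc3nc4ccccc4nc3c2C12C(=O)N(Cc1cnnn1-c1ccc([N+](=O)[O-])cc1)c1ccccc12` gives > 50000 nM in this assay, again only a limit.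
Compound 3 `N#CC1=C(N)Oc2c(N)cc3nc4ccccc4nc3c2C12C(=O)N(Cc1cnnn1-c1cc(Cl)ccc1Cl)c1ccccc12` gives > 50000 nM in this assay, again only a limit.

Compound 3 therefore stands at the limit, and so do the two others; nothing in these three numbers puts any of them ahead of or behind another. Every step among them leaves the same picture: a step that the two limits leave unreadable from compound 1 to compound 2, a step that the two limits leave unreadable from compound 1 to compound 3 and a step that the two limits leave unreadable from compound 2 to compound 3 are all unreadable, because of the limit of > 50000 nM in this assay, at which 3 of the 3 values shown sit. Each of those steps swaps the aryl group on the same aromatic nitrogen, which is exactly the kind of change that leads to compound 4 `COc1cc(-n2nncc2CN2C(=O)C3(C(C#N)=C(N)Oc4c(N)cc5nc6ccccc6nc5c43)c3ccccc32)c(OC)cc1Cl`, a compound not yet measured: 4-chloro-2,5-dimethoxyphenyl in place of 2,5-dichlorophenyl on an aromatic nitrogen.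

Three swaps of this aryl group have produced no readable change in this assay, so the step from compound 3 to compound 4 is expected to be just as silent, with a step that the limit leaves unreadable from compound 3 to compound 4 as the estimated outcome and a limit the most likely report. Compound 4 is accordingly estimated at 70000 nM in this assay, within a range from 30000 nM to 300000 nM.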

Compound 4, half-maximal inhibitory concentration: > 50000 nM
Compound 4: a limit, no number; the forecaster's own chance of this, stated with the estimate: 85%; the middle value is on the limit's open side.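

Compound 4 also gives only a limit, so its steps from compound 1, compound 2 and compound 3 cannot be read, because all four compounds sit at the same limit: the limit of > 50000 nM in this assay, at which 4 of the 4 values shown sit.

The compounds shown leave open how these four rank against one another in this assay and whether any aryl group on this aromatic nitrogen would give a measurable number.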